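The compounds below may be only part of what the source reports. "The series", "measured", "known", "first", "only" and "open" are said of these compounds alone.

Working notes on the nitro/amino pair in this series.

Compound 1 `COC(=O)c1c(-c2ccc([N+](=O)[O-])cc2)oc2ccccc2c1=O` and compound 2 `COC(=O)c1c(-c2ccc(N)cc2)oc2ccccc2c1=O` share one core; compound 3 `O=c1cc(-c2ccc([N+](=O)[O-])cc2)oc2cc(O)ccc12` and compound 4 `Nc1ccc(-c2cc(=O)c3ccc(O)cc3o2)cc1` share another. The difference between the two cores is not broken down here.

In a functional assay on HT-29 cells (Homo sapiens) for cytotoxicity, read by MTT assay, with a stated time of 6 days (a higher number here means that more compound is needed for the effect, a lower number that less compound is needed), compound 1 gives > 25 ug/mL, which is a limit of the assay and not a number. In this assay compound 2 likewise gives > 25 ug/mL, again a limit. The step that the two limits leave unreadable from compound 1 to compound 2 therefore cannot be read; the change made there is amino in place of nitro on an aromatic carbon.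

In this assay, among the measured compounds shown here, compound 3 gives 6.95 ug/mL, the only number in the set. Compound 3 stands apart from compound 1 and compound 2 only in that it returns a number at all, since the limit of > 25 ug/mL in this assay, at which 2 of the 3 values shown sit, is where the other two values sit.

Compound 4 is not yet measured. It differs from compound 3 by amino in place of nitro on an aromatic carbon. The place description is the same word for word as for the change from compound 1 to compound 2, so this is the same change, but on the core of compound 3. The measured instance of the change gives no readable size, so the expectation for compound 4 rests on compound 3 alone. The step from compound 3 to compound 4 is expected to be about a 1.4-fold higher number from compound 3 to compound 4 (0.16 log units; within the scatter). In this assay compound 4 is expected to give about 10 ug/mL. The expected range for compound 4 runs from 3 ug/mL to 30 ug/mL.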

Compound 4, concentration for half-maximal effect: 4.71 ug/mL
Compound 4: middle estimate off by 2.1-fold (0.33 log units), on the high side; measured number inside the range.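

In this assay, amino in place of nitro on an aromatic carbon gives a 1.5-fold lower number from compound 3 to compound 4 (0.17 log units; within the scatter), so on the core of compound 3 this change, para to a large group, leaves the read-out within the scatter. The same change on the core of compound 1 cannot be read, and no size can be set beside the new step, because both members of that pair return a limit rather than a number: the limit of > 25 ug/mL in this assay, at which 2 of the 4 values shown sit. The result therefore shows only that, on one core, nitro and amino are not told apart in this assay; it does not show whether the change carries over from one core to the other, since a single readable instance offers no comparison.

Open, from the compounds shown here alone, is whether other groups at the same place, such as a methoxy, a carboxylic acid or a dimethylamino, would also stay within the scatter of compound 3 and compound 4, or would move the number beyond it. Also open is what the methyl ester and the hydroxyl each contribute on their cores, as the compounds shown do not separate these two groups from the rest of each core.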